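The source may report more compounds than this note shows. Statements on the series, on what has been measured and on what is new or still open speak of the compounds shown alone.

Compound 2: `CC(=O)NC(=S)Nc1ccccc1` — 2350 nM
Compound 3: `CC(=O)NC(=S)Nc1ccc(Br)cc1` — 1640 nM
Compound 1: `CC(=O)NC(=S)Nc1ccc(Oc2ccccc2)cc1` — 3700 nM

All three numbers come from an assay for inhibition of epoxide hydrolase 1 (Homo sapiens), read by fluorescence, using microsomes; a lower number here means a stronger inhibitor, a higher number a weaker inhibitor. They sit close together: compound 2 falls in the middle of the three, and its gap to compound 3 and its gap to compound 1 are both within the usual scatter, so none of the three can be called a stronger or weaker inhibitor than another on this evidence.

Compound 4 is `CC(=O)NC(=S)Nc1ccccc1C`, and its number in this assay is not yet known. Compared with compound 2 it carries one change: methyl in place of hydrogen on an aromatic carbon.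

Going by the values given here, only one measured step bears on this change, and only loosely: the one in which a bromine atom takes the seat of a ring hydrogen, with the result a 1.4-fold lower number from compound 2 to compound 3 (0.16 log units; within the scatter). Among the compounds with values here, no measured pair shows a methyl entering anywhere, and no pair shows any group entering ortho to a group of 7 heavy atoms. Within the data shown here, the one relevant step changed nothing beyond the scatter, so for compound 4 the expectation is a step of no more than the scatter, a 1.0-fold lower number from compound 2 to compound 4 (0.01 log units; within the scatter), in no particular direction.

The estimated number for compound 4 is therefore 2300 nM, with a range from 1000 nM to 5500 nM.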

Compound 4, half-maximal inhibitory concentration: 1500 nM
For compound 4 the middle estimate is 1.5-fold (0.19 log units) above the measured one; measured number inside the range.
By their numbers in this assay, from the lowest: compounds 4, 3, 2 and 1 (each within the scatter of the next, the first and the last beyond it).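

In this assay, methyl in place of hydrogen on an aromatic carbon, ortho to a group of 7 heavy atoms, gives a 1.6-fold lower number from compound 2 to compound 4 (0.19 log units; within the scatter), so at this position a single added carbon leaves the number within the scatter of the unsubstituted parent. Going by these compounds alone, this is the first measured pair in which a methyl enters and the first with any group at this place; the only earlier replacement of a ring hydrogen, bromo in compound 3, gave a 1.4-fold lower number from compound 2 to compound 3 (0.16 log units; within the scatter) and so also stayed within the scatter, but it says nothing direct about this position. No measured information is available to explain why the number behaves this way.

One small group at this place cannot show how much room for change the position offers. On these data alone, whether a longer chain such as propyl, an amine or a carboxylic acid here would move the number beyond the scatter remains open, as does whether a methyl on another carbon of the ring would act like this one.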